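Methyl on the Saturated Ring Carbon and Cytotoxicity

A few compounds are considered here, and "the series" means these few. Any claim that something is new, unique, unknown or untested is made for them only; others in the source may bear on it.

Three compounds of one series were examined for cytotoxicity. Compound 1 `O=[N+]([O-])c1cn2c(n1)OC(COc1ccc(-c3ccc(F)nc3F)nc1)CC2`, compound 2 `CC1(COc2ccc(-c3ccc(F)nc3F)nc2)CCn2cc([N+](=O)[O-])nc2O1` and compound 3 `O=[N+]([O-])c1cn2c(n1)OC(COc1ccc(-c3ccc(F)cc3F)cn1)CC2` share a nitroimidazole fused to a six-membered non-aromatic ring carrying one nitrogen and one oxygen, and they were all run in an ADME assay on MRC5 cells (Homo sapiens) for cytotoxicity, read by resazurin assay, with a stated time of 72 h; on this read-out lower numbers stand for stronger inhibition and higher numbers for weaker inhibition. In this assay compound 1 gives > 64000 nM, which is a limit of the assay and not a number. Compound 2 gives > 64000 nM in this assay, likewise a limit. Compound 3 gives > 64000 nM in this assay, again a limit. All three values therefore sit at the limit of > 64000 nM in this assay, at which 3 of the 3 values shown sit.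

The change from compound 1 to compound 2 is methyl in place of hydrogen on a saturated ring carbon, and in this assay it shows up as a step that the two limits leave unreadable from compound 1 to compound 2. The difference between the core of compound 1 and the core of compound 3 is not broken down here.

Compound 4 `CC1(COc2ccc(-c3ccc(F)cc3F)cn2)CCn2cc([N+](=O)[O-])nc2O1` has not yet been measured in this assay. It differs from compound 3 by methyl in place of hydrogen on a saturated ring carbon, the same change that separates compound 1 from compound 2. In this assay the step is expected to be a step that the limit leaves unreadable from compound 3 to compound 4, because compound 1 and compound 2 both sit at the limit of > 64000 nM in this assay, at which 3 of the 3 values shown sit. Compound 4 is accordingly expected to give about 120000 nM, with a range estimated from 45000 nM to 400000 nM, and it is expected that the assay will most likely again report only a limit.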

Compound 4, half-maximal inhibitory concentration: > 64000 nM
Compound 4 was reported as a limit (the forecaster's own chance of this, stated with the estimate: 90%); the middle value does not contradict the limit.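

In this assay compound 4 gives > 64000 nM, which is a limit of the assay and not a number. No step can be read from compound 3 to compound 4, because both values are the same limit: the limit of > 64000 nM in this assay, at which 4 of the 4 values shown sit.

The compounds shown leave open whether methyl in place of hydrogen on a saturated ring carbon changes cytotoxicity at all, and how far any of the four compounds lies beyond that limit.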